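Swapping the Ring on the Anilino Nitrogen

This account rests on a few compounds, and the source may have more. Where it says the series, first, only, none or still open, it means among the compounds named here.

Compound 1 `CC(C)c1ccc(-c2nc(SCc3cn(CC(=O)NC(=O)Nc4ccccn4)nn3)nc(Nc3ccccc3Cl)c2C#N)cc1`: 43700 nM
Compound 2 `CC(C)c1ccc(-c2nc(SCc3cn(CC(=O)NC(=O)Nc4ccccn4)nn3)nc(Nc3ccc(Cl)cc3)c2C#N)cc1`: > 64000 nM
Compound 3 `CC(C)c1ccc(-c2nc(SCc3cn(CC(=O)NC(=O)Nc4ccccn4)nn3)nc(Nc3cccc([N+](=O)[O-])c3)c2C#N)cc1`: 25900 nM

Three compounds share one core and differ only in the ring attached to a nitrogen on an aromatic ring. In a functional assay on MCF7 cells (Homo sapiens) for inhibition, read by MTT assay, with a stated time of 72 h (a lower number here means a stronger inhibitor, a higher number a weaker inhibitor), compound 1 gives 43700 nM, the highest of the two numbers obtained; the nearest, compound 3, gives 25900 nM. Compound 2 reaches only a limit of this assay, > 64000 nM. The steps are small: a 1.7-fold lower number from compound 1 to compound 3 (0.23 log units; within the scatter), and an at least 1.4-fold higher number from compound 1 to compound 2 (0.16 log units; that floor lies within the scatter). Between the other two, an at least 2.4-fold lower number from compound 2 to compound 3 (0.39 log units; beyond the scatter).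

Compound 4 `CC(C)c1ccc(Nc2nc(SCc3cn(CC(=O)NC(=O)Nc4ccccn4)nn3)nc(-c3ccc(C(C)C)cc3)c2C#N)cc1` has not yet been measured in this assay. Relative to compound 1 the change is 4-isopropylphenyl in place of 2-chlorophenyl on a nitrogen on an aromatic ring. The step that bears most directly on it is the one in which 4-chlorophenyl replaced 2-chlorophenyl, where compound 2 went to a limit, so a 4-isopropylphenyl ring in the same place is expected to move the number in the same direction, by a modest amount if at all. The step from compound 1 to compound 4 in this assay is therefore estimated as a 1.5-fold higher number from compound 1 to compound 4 (0.17 log units; within the scatter). For compound 4 the expected value is 65000 nM, within a range of 25000 nM to 170000 nM.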

Compound 4, half-maximal inhibitory concentration: 28600 nM
Compound 4: the middle estimate sits 2.3-fold (0.36 log units) above what was measured; low and high end bracket the measured number.
By their numbers in this assay, from the lowest: compounds 3, 4 and 1 (each within the scatter of the next). At a limit, above all of these: compound 2.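

Among these compounds, the isopropyl in place of chloro on an aromatic carbon gives an at least 2.2-fold lower number from compound 2 to compound 4 (0.34 log units; beyond the scatter), so in this assay the 4-isopropylphenyl ring does not share the result of the 4-chlorophenyl ring, and this is the first step from compound 2 that isolates a change on the ring itself. Against the other rings, the new group gives a 1.5-fold lower number from compound 1 to compound 4 (0.18 log units; within the scatter) and a 1.1-fold higher number from compound 3 to compound 4 (0.04 log units; within the scatter), so compound 1, compound 3 and compound 4 cannot be told apart here, even though the 2-chlorophenyl, 3-nitrophenyl and 4-isopropylphenyl rings carry quite different groups. Compound 2 stands at a limit of this assay, not at a number, so its steps give only a floor: the limit of > 64000 nM in this assay, at which 1 of the 4 values shown sits.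

The compounds shown leave open what an amine, a carboxylic acid or a longer chain would do on this ring in place of the isopropyl. They also leave open whether any ring on this nitrogen can take the number clearly below those of compound 3 and compound 4, which so far differ by no more than the scatter.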